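Methoxyphenyl in place of methylphenyl on a ring nitrogen

The compounds below may be only part of what the source reports. "The series", "measured", "known", "first", "only" and "open" are said of these compounds alone.

Compounds measured in a functional assay on CHO-K1 cells for antagonist activity at transient receptor potential cation channel subfamily V member 1 (Homo sapiens), read by FLIPR; a lower number here means a stronger inhibitor, a higher number a weaker inhibitor:
compound 1, `CC(C(=O)NCc1ccc(C(F)(F)F)nc1Nc1ccccc1)c1ccc(NS(C)(=O)=O)c(F)c1`, 1400 nM
compound 2, `CC(C(=O)NCc1ccc(C(F)(F)F)nc1N1CCC(C(F)(F)F)CC1)c1ccc(NS(C)(=O)=O)c(F)c1`, 31 nM
compound 3, `Cc1cccc(N2CCN(c3nc(C(F)(F)F)ccc3CNC(=O)C(C)c3ccc(NS(C)(=O)=O)c(F)c3)CC2)c1`, 39.2 nM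

Compound 3 and compound 2 give numbers that lie within the scatter of each other, while compound 1 gives a number well above both, a gap that lies beyond the scatter. For the measured compounds named here, the one measured step, a 45-fold lower number from compound 1 to compound 2 (1.65 log units; beyond the scatter), concerns a change on an aromatic carbon of the shared core, not the aryl group on the ring amine nitrogen.

Compound 4, `COc1ccc(N2CCN(c3nc(C(F)(F)F)ccc3CNC(=O)C(C)c3ccc(NS(C)(=O)=O)c(F)c3)CC2)cc1`, differs from compound 3 in that change: 4-methoxyphenyl in place of 3-methylphenyl on an amine nitrogen in a ring. Going by the values given here, no measured step touches this position, so nothing in the data says which way it moves this assay. In the absence of such a step, compound 4 is expected to give 40 nM, with a range from 15 nM to 120 nM. The step of a 1.0-fold higher number from compound 3 to compound 4 (0.01 log units; within the scatter) is therefore estimated to remain within the scatter.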

Compound 4, half-maximal inhibitory concentration: 44.5 nM
Compound 4: middle estimate off by 1.1-fold (0.05 log units), on the low side; the range from low to high includes it.
By their numbers in this assay, from the lowest: compounds 2, 3 and 4 (each within the scatter of the next); then compound 1.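

In this assay the first step measured at this position, a 1.1-fold higher number from compound 3 to compound 4 (0.06 log units; within the scatter), shows that 4-methoxyphenyl can take the place of 3-methylphenyl on the amine nitrogen in the ring with no difference beyond the scatter. This one exchange moves the substituent on the phenyl ring, replaces methyl with methoxy and adds a hydrogen-bond acceptor, and compound 3 and compound 4 still read alike. No evidence is available that accounts for this result.

Since the substituent and its place on the phenyl ring change together, the compounds shown do not separate what each contributes. They also leave open whether this nitrogen would keep a similar reading with an unsubstituted phenyl, a pyridyl ring, or a phenyl ring bearing a carboxylic acid or an amine.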